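Lengthening the Amine Side Chain on a Shared Core

The source may hold more compounds than are shown below. What is called first, only, known or untested is meant among the compounds shown, and "the series" means these compounds.

Measured so far:
compound 1, `CN(C)CCNc1nc(-c2ccc(NC(=O)Nc3ccc(F)cc3)cc2)nc2c(Cl)c(Cl)sc12`, 1240 nM
compound 2, `CN(C)CCNc1nc(-c2ccc(NC(=O)Nc3ccc(Cl)cc3Cl)cc2)nc2c(Cl)c(Cl)sc12`, 3500 nM

In a functional assay on MDA-MB-231 cells (Homo sapiens) for cytotoxicity, read by MTT assay, with a stated time of 72 h (on this read-out higher numbers stand for weaker inhibition and lower numbers for stronger inhibition), compound 1 gives 1240 nM, the lower of the two numbers seen; compound 2 gives 3500 nM. Among the measured compounds shown here, the only step between measured compounds, a 2.8-fold higher number from compound 1 to compound 2 (0.45 log units; beyond the scatter), changes the aryl group on the urea nitrogen. Compound 3, `CCN(CC)CCCNc1nc(-c2ccc(NC(=O)Nc3ccc(F)cc3)cc2)nc2c(Cl)c(Cl)sc12`, has not yet been measured. It differs from compound 1 at another part of the molecule: (diethylamino)methyl in place of dimethylamino on a saturated chain carbon, two bonds along the chain from a nitrogen on an aromatic ring. Because the step from compound 1 to compound 2 a 2.8-fold higher number from compound 1 to compound 2 (0.45 log units; beyond the scatter) concerns the urea aryl and not the amine side chain, it offers no direct guide here. For the measured compounds named here, no measured pair varies this chain, so the expectation rests on compound 1 alone. A step of no size beyond the scatter is expected, a 1.0-fold lower number from compound 1 to compound 3 (0.01 log units; within the scatter). Compound 3 is therefore estimated at 1200 nM, with a range from 450 nM to 3200 nM.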

Compound 3, half-maximal inhibitory concentration: 1630 nM
For compound 3 the middle estimate is 1.4-fold (0.13 log units) below the measured one; the measured number falls inside the stated range.
By their numbers in this assay, from the lowest: compounds 1 and 3 (each within the scatter of the next); then compound 2.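

Among the compounds shown here, the amine side chain is varied here for the first time: in this assay, replacing 2-(dimethylamino)ethyl with 3-(diethylamino)propyl gives a 1.3-fold higher number from compound 1 to compound 3 (0.12 log units; within the scatter). At this place, then, going from dimethylamino with 3 heavy atoms to (diethylamino)methyl with 6 leaves no difference that can be told from the scatter, unlike the change of urea aryl group between compound 1 and compound 2. Nothing measured here bears on the reason for this result.

This single step alters the chain length and the groups on the amine nitrogen together, so 3-(dimethylamino)propyl would be needed to tell those two changes apart. Going by these compounds, it also remains open how a primary amine or a longer chain such as 4-(diethylamino)butyl would read out in this assay.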